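The source may hold more compounds than are shown below. What is called first, only, known or untested is meant among the compounds shown, and "the series" means these compounds.

Three small compounds have been measured in a functional assay on B16 cells (Mus musculus) for inhibition, with a stated time of 3 days (on this read-out lower numbers stand for stronger inhibition and higher numbers for weaker inhibition), and their numbers sit close together. Compound 1 (`COc1ccc(/C(C)=N/NC(N)=S)cc1`) gives 2700 nM in this test, compound 2 (`CC/C(=N\NC(N)=S)c1ccc(C)cc1`) gives 2600 nM and compound 3 (`CC/C(=N\N=C(\N)S)c1ccc(Cl)cc1`) gives 2900 nM on the same read-out. Compound 3 therefore stands level with the other two: its gaps to compound 1 and to compound 2 lie within the usual scatter of repeated measurements, so these numbers support no ranking.

The next compound, compound 4 (`CC/C(=N\N=C(\N)S)c1ccc(OC)cc1`), differs from compound 3 in one place: methoxy in place of chloro on an aromatic carbon, para to a group of 8 heavy atoms (methoxy in place of chloro on an aromatic carbon). Among the measured compounds shown here, no two measured compounds differ in just one place, so the data give no direct measure of this swap. The best guide is the narrow spread of the three numbers, and compound 1, which also carries a methoxy group, gives 2700 nM without leaving that spread. In this assay no step beyond the scatter is therefore expected, and the estimated change is small (a 1.1-fold lower number from compound 3 to compound 4 (0.03 log units; within the scatter)). For compound 4 the estimated value is 2700 nM (expected range 1400 nM to 5200 nM).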

Compound 4, half-maximal inhibitory concentration: 4000 nM
Estimate against measurement, compound 4: 1.5-fold (0.17 log units) below; the measured number falls inside the stated range.
By their numbers in this assay, from the lowest: compounds 2, 1, 3 and 4 (each within the scatter of the next).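

Among the compounds shown here, the step from chloro to methoxy, on an aromatic carbon para to a group of 8 heavy atoms, gives the first direct comparison of a single change: in this assay it reads a 1.4-fold higher number from compound 3 to compound 4 (0.14 log units; within the scatter) and so supports no ranking of the two compounds. At this position, then, replacing one chlorine atom with a methoxy group, which has one more heavy atom and one hydrogen-bond acceptor, produces no difference that can be told apart from the variation between repeated measurements. No measured information on either group bears on this result, so the step stands as a plain observation without an explanation.

Chloro and methoxy are the only two groups compared directly at this position, so it remains open whether an amine, a carboxylic acid or a bulkier group such as tert-butyl would also leave the number within the scatter or would move it clearly. Going by these compounds, it also remains open whether a longer chain in place of the ethyl group on the shared core would change the number, and whether the chloro-to-methoxy swap would give a similar step on a different core.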